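From Difluorophenyl to Nitrophenyl on the Shared Core

This account rests on a few compounds, and the source may have more. Where it says the series, first, only, none or still open, it means among the compounds named here.

Measured so far:
compound 1, `CN(C(=O)NC(=O)c1c(Cl)cccc1Cl)c1nc(C(F)(F)F)c(C(=O)N/N=C/c2ccccc2C(F)(F)F)s1`, in a functional assay on BCG823 cells (Homo sapiens) for inhibition, read by MTT assay, with a stated time of 72 h (on this read-out lower numbers stand for stronger inhibition and higher numbers for weaker inhibition), gives 4.12 ug/mL.
compound 2, `CN(C(=O)NC(=O)c1c(F)cccc1F)c1nc(C(F)(F)F)c(C(=O)N/N=C/c2ccccc2C(F)(F)F)s1`, in this assay gives 17 ug/mL.

Among the measured compounds shown here, compound 2 stands at the higher of the two numbers in this assay; the only neighbour is compound 1, and the step of a 4.1-fold higher number from compound 1 to compound 2 (0.62 log units; beyond the scatter) lies beyond the scatter. Compound 3, `CN(C(=O)NC(=O)c1cccc([N+](=O)[O-])c1)c1nc(C(F)(F)F)c(C(=O)N/N=C/c2ccccc2C(F)(F)F)s1`, keeps the shared core and alters the group on the carbonyl carbon: 3-nitrophenyl in place of 2,6-difluorophenyl on a carbonyl carbon. For the measured compounds named here, the single measured step, from compound 1 to compound 2, swaps one halogenated ring for another at that carbonyl carbon, and it is of modest size. It does not show what a nitrophenyl ring does there, since neither measured compound carries a nitro group, so nothing measured bears directly on the change from compound 2 to compound 3. Going by the values given here, the account therefore expects no step of a settled direction beyond the scatter, and the estimate for compound 3 in this assay is 10 ug/mL, with a range from 3 ug/mL to 35 ug/mL, a step of a 1.7-fold lower number from compound 2 to compound 3 (0.23 log units; within the scatter) that is expected rather than known.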

Compound 3, half-maximal inhibitory concentration: 3.97 ug/mL
Compound 3: middle estimate off by 2.5-fold (0.40 log units), on the high side, and the stated range covers the measured number.
By their numbers in this assay, from the lowest: compounds 3 and 1 (each within the scatter of the next); then compound 2.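

In this assay, the picture at the carbonyl carbon now extends beyond halogenated rings. Among the compounds shown here, the step reads a 4.3-fold lower number from compound 2 to compound 3 (0.63 log units; beyond the scatter) and shows that a ring with no halogen, 3-nitrophenyl, can take the place of 2,6-difluorophenyl with a change beyond the scatter, leaving the difluorophenyl ring as the one compound that stands apart from the other two. The comparison of the remaining pair reads a 1.0-fold lower number from compound 1 to compound 3 (0.02 log units; within the scatter) and shows that 3-nitrophenyl and 2,6-dichlorophenyl, two rings that share no substituent, are not separated by this assay, while nothing available accounts for why these two rings match or why 2,6-difluorophenyl differs from both.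

Whether this match extends to other rings stays open, as the compounds shown place only three substituted phenyl rings on this carbonyl carbon and carry the nitro group in just one arrangement. As far as these compounds go, it also remains open how a phenyl ring bearing an amine or a carboxylic acid, or a plain alkyl chain in place of the ring, would compare with compound 3 on the shared core.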